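Moving a hydroxyl group on a pyridine-linked phenyl ring

The source may hold more compounds than are shown below. What is called first, only, known or untested is meant among the compounds shown, and "the series" means these compounds.

Compound 1 `Oc1cccc(-c2cc(-c3ccco3)cc(-c3ccccc3O)n2)c1` is measured in a functional assay on T47D cells (Homo sapiens) for cytotoxicity, read by CCK-8 assay (a lower number here means a stronger inhibitor, a higher number a weaker inhibitor), and gives 820 nM. Compound 2 `Oc1ccc(-c2cc(-c3ccco3)cc(-c3ccccc3O)n2)cc1` differs from it by 4-hydroxyphenyl in place of 3-hydroxyphenyl on an aromatic carbon. For compound 2 the value in this assay is only a limit of the assay, > 50000 nM. The step of an at least 60-fold higher number from compound 1 to compound 2 (1.78 log units; beyond the scatter) is therefore a large loss of potency.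

Compound 3 `Oc1ccc(-c2cc(-c3cccnc3)cc(-c3cccc(O)c3)n2)cc1` carries a different set of groups on the shared core; the difference between the two cores is not broken down here. In this assay compound 3 also reaches only a limit, > 50000 nM. Compound 4 `Oc1ccc(-c2cc(-c3cccnc3)cc(-c3ccc(O)cc3)n2)cc1` is not yet measured and differs from compound 3 by 4-hydroxyphenyl in place of 3-hydroxyphenyl on an aromatic carbon. This is the same kind of change as from compound 1 to compound 2, though the surroundings differ: there the place was meta to a 2-hydroxyphenyl group and meta to a furan-2-yl group, here it is meta to a 4-hydroxyphenyl group and meta to a pyridin-3-yl group.

Because compound 3 already sits at the limit of > 50000 nM in this assay, at which 2 of the 3 values shown sit, the earlier loss cannot repeat visibly, and compound 4 is expected to stay at the limit, with an estimated step that the limit leaves unreadable from compound 3 to compound 4. The estimate for compound 4 in this assay is 60000 nM, expected between 20000 nM and 200000 nM.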

Compound 4, half-maximal inhibitory concentration: 2030 nM
For compound 4 the middle estimate is 30-fold (1.47 log units) above the measured one; the measured number lies below the stated range.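

In this assay, putting 4-hydroxyphenyl in place of 3-hydroxyphenyl gives an at least 24-fold lower number from compound 3 to compound 4 (1.39 log units; beyond the scatter), so on this core the change brings a large gain in potency. On these data alone, compound 3 reaches only a limit of the assay, > 50000 nM, so the true size of this step stays unknown. Set beside the earlier step, the same change runs in the opposite direction, which shows that its effect does not carry over between these two cores, but not which of the other differences between them decides the outcome: the same change on two cores in this assay, an at least 60-fold higher number (1.78 log units; beyond the scatter) from compound 1 to compound 2 and an at least 24-fold lower number (1.39 log units; beyond the scatter) from compound 3 to compound 4, at least 1500-fold (3.17 log units) apart, beyond the scatter of two such steps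

As far as these compounds go, it stays open whether the swap of furan-2-yl for pyridin-3-yl, the other hydroxyphenyl group, or the two together set the direction of the step. Also open, from the compounds shown here alone, is what an amine or a carboxylic acid in place of the moved hydroxyl group would do on either core.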